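Losing the azetidine ring from compound 3

The source may report more compounds than this note shows. Statements on the series, on what has been measured and on what is new or still open speak of the compounds shown alone.

In an ADME assay on MT4 cells (Homo sapiens) for cytotoxicity, read by MTT assay, with a stated time of 5 days (a higher number here means that more compound is tolerated, a lower number that less compound is tolerated), compound 1 (`Cc1cc(C)cc(S(=O)(=O)c2c(C(=O)N[C@H]3CCNC3)[nH]c3ccc(Cl)cc23)c1`) gives 10000 nM, and compound 2 (`Cc1cc(C)cc(S(=O)(=O)c2c(C(=O)N[C@@H]3CCN(Cc4cccnc4)C3)[nH]c3ccc(Cl)cc23)c1`) gives 36500 nM. Compound 3 (`Cc1cc(C)cc(S(=O)(=O)c2c(C(=O)NC3CN(S(C)(=O)=O)C3)[nH]c3ccc(Cl)cc23)c1`) gives no number, only a limit of the assay, > 252000 nM. Its steps from both other compounds are beyond the scatter, which puts it at the tolerated end of the three.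

Compound 4 (`Cc1cc(C)cc(S(=O)(=O)c2c(C(=O)NS(C)(=O)=O)[nH]c3ccc(Cl)cc23)c1`) has methylsulfonyl in place of 1-(methylsulfonyl)azetidin-3-yl on an amide-type nitrogen. For the measured compounds named here, no measured step makes this exact exchange, but all three measured steps alter the group at this amide-type nitrogen. They are a 3.7-fold higher number from compound 1 to compound 2 (0.56 log units; beyond the scatter), an at least 25-fold higher number from compound 1 to compound 3 (1.40 log units; beyond the scatter) and an at least 6.9-fold higher number from compound 2 to compound 3 (0.83 log units; beyond the scatter). These show that this assay responds to changes at this place, sometimes strongly.

Compound 4 keeps the methylsulfonyl group that compound 2 and compound 1 lack, so a fall to the level of compound 1 at 10000 nM is not expected. Compound 4 also loses the ring, so an unchanged reading cannot be assumed either. The expected result in this assay is a modest move toward a lower number, estimated as an at least 2.5-fold lower number from compound 3 to compound 4 (0.40 log units; beyond the scatter). For compound 4 the estimate is 100000 nM, with an expected range of 25000 nM to 280000 nM.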

Compound 4, half-maximal cytotoxic concentration: 40200 nM
For compound 4 the middle estimate is 2.5-fold (0.40 log units) above the measured one, and the stated range covers the measured number.
By their numbers in this assay, from the lowest: compound 1; then compounds 2 and 4 (each within the scatter of the next). At a limit, above all of these: compound 3.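

In this assay, putting methylsulfonyl in place of 1-(methylsulfonyl)azetidin-3-yl on the amide-type nitrogen gives an at least 6.2-fold lower number from compound 3 to compound 4 (0.79 log units; beyond the scatter), so a methylsulfonyl group in itself does not preserve the reading of compound 3. The new compound also shows that quite different groups at this nitrogen can read alike: the exchange for 1-((pyridin-3-yl)methyl)pyrrolidin-3-yl gives a 1.1-fold higher number from compound 2 to compound 4 (0.04 log units; within the scatter), whereas the exchange for pyrrolidin-3-yl gives a 4.0-fold higher number from compound 1 to compound 4 (0.60 log units; beyond the scatter). The first of these steps has only a lower bound on its size, since the reading for compound 3 is a limit of the assay and not a number: the limit of > 252000 nM in this assay, at which 1 of the 4 values shown sits.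

The compounds shown do not separate the azetidine ring from the methylsulfonyl group it carries, and what the same ring would give with a free amine or an acetyl group on its nitrogen stays open. Also open, going by these compounds, is how a simple methyl group on the amide-type nitrogen would read, which would show whether the methylsulfonyl group of compound 4 counts at all at this place.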